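This account rests on a few compounds, and the source may have more. Where it says the series, first, only, none or still open, it means among the compounds named here.

Of the compounds shown here, three built on one shared core have been measured in a functional assay on MCF7 cells (Homo sapiens) for antiproliferative activity, read by MTT assay, with a stated time of 24 h; a higher number here means a weaker inhibitor, a lower number a stronger inhibitor. Compound 1 `Cc1cc(OCc2nnc(SCc3ccccc3)o2)cc2oc(=O)cc(C)c12` reaches only a bound of the assay, > 100000 nM, which is a limit and not a number. Compound 2 `Cc1cc(OCc2nnc(SCc3ccc(F)c(F)c3)o2)cc2oc(=O)cc(C)c12` gives 33300 nM in this assay. Compound 3 `Cc1cc(OCc2nnc(SCc3ccc(Cl)cc3Cl)o2)cc2oc(=O)cc(C)c12` also returns a limit rather than a number, < 5000 nM, so its standing is known only as a bound. The measured steps all vary the aryl group on the saturated chain carbon bound to a sulfur: an at least 3.0-fold lower number from compound 1 to compound 2 (0.47 log units; beyond the scatter), an at least 20-fold lower number from compound 1 to compound 3 (1.30 log units; beyond the scatter) and an at least 6.6-fold lower number from compound 2 to compound 3 (0.82 log units; beyond the scatter). Compound 4 `CCS(=O)(=O)c1nnc(COc2cc(C)c3c(C)cc(=O)oc3c2)o1` departs from compound 3 differently: ethylsulfonyl in place of (2,4-dichlorobenzyl)sulfanyl on an aromatic carbon. Among the measured compounds shown here, no measured step removes the benzyl group altogether, so the three steps bear on this change only loosely; they show the number falling as halogens were added to that ring, and compound 1, carrying the plain phenyl, sits at the limit of > 100000 nM in this assay, at which 1 of the 3 values shown sits. Compound 4 keeps no ring at this position. The step from compound 3 to compound 4 in this assay is therefore expected to be a rise, an at least 10-fold higher number from compound 3 to compound 4 (1.00 log units; beyond the scatter). The value of compound 4 in this assay is estimated at 50000 nM, most likely between 10000 nM and 200000 nM.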

Compound 4, half-maximal inhibitory concentration: > 100000 nM
Compound 4: a limit, no number; the forecaster's own chance of this, stated with the estimate: 50%; at least 2.0-fold (0.30 log units) between middle value and limit.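

In this assay compound 4 returns a limit and no number, yet the replacement of the ring-bearing (2,4-dichlorobenzyl)sulfanyl by ethylsulfonyl still gives an at least 20-fold higher number from compound 3 to compound 4 (1.30 log units; beyond the scatter), and the replacement of (3,4-difluorobenzyl)sulfanyl gives an at least 3.0-fold higher number from compound 2 to compound 4 (0.47 log units; beyond the scatter). The earlier compounds shown here varied only the halogens on a retained ring, whereas these steps show that the activity seen in compound 2 and compound 3 does not survive a change at this position to a group with no ring, and compound 4 shares its limit with compound 1: the limit of > 100000 nM in this assay, at which 2 of the 4 values shown sit. The step from compound 1 to compound 4 cannot be read, as both values are limits, so ethylsulfonyl and benzylsulfanyl cannot be ranked against each other.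

The change to compound 4 removes the ring and alters the sulfur at once, so it remains open which of the two accounts for the rise; an ethylsulfanyl group or a (2,4-dichlorobenzyl)sulfonyl group at this position would separate them. Also open, as far as these compounds go, is how an amine at this position, or a longer chain ending in a halogenated phenyl ring, would read in this assay.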